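The compounds below may be only part of what the source reports. "The series", "measured", "known", "first", "only" and "open" are said of these compounds alone.

Working notes on the series. Going by the values given here, compound 2 `COc1cc(-c2nn(-c3ccccc3)cc2C(=O)/C=C\Nc2ccc(Cl)cc2)cc(OC)c1OC` is the only member with a number in a functional assay on HT-29 cells (Homo sapiens) for antiproliferative activity, read by MTT assay, with a stated time of 48 h; on this read-out lower numbers stand for stronger inhibition and higher numbers for weaker inhibition: in this assay compound 2 gives 7680 nM. Among the compounds with values here, compound 1 `O=C(/C=C\Nc1ccc(C(F)(F)F)cc1)c1cn(-c2ccccc2)nc1-c1ccc(Cl)cc1` differs from compound 2 in more than one place, so no single step connects the two. In this assay compound 1 gives only a limit, > 50000 nM; this is the limit of the limit of > 50000 nM in this assay, at which 1 of the 2 values shown sits, and the value is a limit of the assay rather than a number.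

Compound 3 `COc1cc(-c2nn(-c3ccccc3)cc2C(=O)/C=C\Nc2ccc(C(F)(F)F)cc2)cc(OC)c1OC` differs from compound 2 in one place: trifluoromethyl in place of chloro on an aromatic carbon. Within the data shown here, no measured pair shows this change alone. Compound 1 carries the same 4-(trifluoromethyl)phenyl amino group and gives only the limit > 50000 nM in this assay. On that basis the step from compound 2 to compound 3 is expected to be a weakening beyond the scatter, a 2.3-fold higher number from compound 2 to compound 3 (0.37 log units; beyond the scatter). For compound 3 the estimate in this assay is 18000 nM, with a range from 6000 nM to 50000 nM, and a real chance that only a limit is returned.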

Compound 3, half-maximal inhibitory concentration: > 50000 nM
Compound 3: a limit, no number; the forecaster's own chance of this, stated with the estimate: 35%; middle value at least 2.7-fold (0.44 log units) away from the limit.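

In this assay, going by these compounds alone, trifluoromethyl in place of chloro on an aromatic carbon, para to a large group, gives an at least 6.5-fold higher number from compound 2 to compound 3 (0.81 log units; beyond the scatter), the first readable single-place step. With the 3,4,5-trimethoxyphenyl group held constant, this position therefore responds to the change, and only the chloro member, compound 2, keeps a number among the compounds shown. Compound 3 gives a limit, as does compound 1, and the step between these two cannot be read, so the effect of 3,4,5-trimethoxyphenyl in place of 4-chlorophenyl remains unseen with the (4-(trifluoromethyl)phenyl)amino group: the limit of > 50000 nM in this assay, at which 2 of the 3 values shown sit.

The compounds shown leave open whether the loss belongs to trifluoromethyl alone or whether other groups on the same aromatic carbon, such as fluoro, methoxy, a nitrile or a carboxylic acid, or simply hydrogen, would also fall away from compound 2. They also leave open how much the 3,4,5-trimethoxyphenyl group contributes to the number of compound 2, a question that the 4-chlorophenyl analogue carrying the (4-chlorophenyl)amino group would address directly.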